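This account rests on a few compounds, and the source may have more. Where it says the series, first, only, none or still open, it means among the compounds named here.

Measured compounds:
Compound 1, `CN1CCN(C[C@H]2CN(c3ccc(-n4cc(-c5ccccn5)cn4)c(F)c3)C(=O)O2)CC1` — 1690000 nM
Compound 2, `O=C1O[C@@H](Cn2ccnc2)CN1c1ccc(-n2cc(-c3ccccn3)cn2)c(F)c1` — 12300 nM

In a physicochemical assay for solubility, read by HPLC, with a stated time of 24 h (on this read-out higher numbers stand for higher solubility and lower numbers for lower solubility), compound 1 gives 1690000 nM, while compound 2 gives 12300 nM. Among the measured compounds shown here, compound 2 therefore stands lowest of the two numbers, and the only step in this assay, a 140-fold lower number from compound 1 to compound 2 (2.14 log units; beyond the scatter), shows how strongly the group on the saturated chain carbon bound to a saturated ring carbon can move this read-out.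

Compound 3, `CN(C)S(=O)(=O)NC[C@H]1CN(c2ccc(-n3cc(-c4ccccn4)cn3)c(F)c2)C(=O)O1`, is not yet measured. It differs from compound 2 in one place: (dimethylsulfamoyl)amino in place of 1H-imidazol-1-yl on a saturated chain carbon bound to a saturated ring carbon. For the measured compounds named here, the step from compound 1 to compound 2 bears on this change only in part, since it exchanged a different pair of groups at the same place; no measured pair shows the (dimethylsulfamoyl)amino group itself. Given the size of that earlier step, a shift in either direction cannot be ruled out, but the account expects a modest one, estimated as a 2.0-fold higher number from compound 2 to compound 3 (0.31 log units; beyond the scatter). Compound 3 is accordingly expected to give about 25000 nM in this assay, estimated to lie between 5000 nM and 120000 nM.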

Compound 3, solubility: 472000 nM
Compound 3: the middle estimate sits 19-fold (1.28 log units) below what was measured, outside the stated range (above it).
By their numbers in this assay, from the lowest: compound 2; then compound 3; then compound 1.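

At the saturated chain carbon bound to a saturated ring carbon, replacing 1H-imidazol-1-yl with (dimethylsulfamoyl)amino, a group with no ring, brings a 38-fold higher number from compound 2 to compound 3 (1.58 log units; beyond the scatter) in this assay, so a step of large size at this place is not confined to the exchange of the two ring groups seen earlier. Replacing 4-methylpiperazin-1-yl with the same group brings only a 3.6-fold lower number from compound 1 to compound 3 (0.55 log units; beyond the scatter), so leaving 4-methylpiperazin-1-yl does not by itself carry the number down as far as it fell with 1H-imidazol-1-yl, and among these three groups it is compound 2 that stands well apart. Nothing at hand accounts for either step or for the order of the three compounds.

The compounds shown leave open how a primary amine, a carboxylic acid or an open-chain tertiary amine would read at this place in this assay. They also leave open whether a longer chain carrying 1H-imidazol-1-yl or (dimethylsulfamoyl)amino would keep the wide gap between these two groups, and whether that gap would hold on a core other than the one shared here.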